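The source may hold more compounds than are shown below. What is called first, only, known or untested is meant among the compounds shown, and "the series" means these compounds.

Of the compounds shown here, three built on one shared core have been tested in a functional assay on HeLa cells (Homo sapiens) for antiproliferative activity, read by MTT assay, with a stated time of 48 h; a higher number here means a weaker inhibitor of growth, a lower number a stronger inhibitor of growth. Compound 1 `CCOC(=O)c1sc2ccc(NCc3c[nH]cn3)cc2c1NC(=O)c1cc(OC)c(OC)c(OC)c1` gives 6790 nM in this assay. Compound 2 `CCOC(=O)c1sc2ccc(NCc3nc[nH]c3C)cc2c1NC(=O)c1ccccc1` gives 23300 nM in this assay. Compound 3 `CCOC(=O)c1sc2ccc(NCc3nc[nH]c3C)cc2c1NC(=O)c1ccc(OC)cc1` gives 8220 nM in this assay, the second highest of the three numbers: it sits within the scatter of compound 1 and beyond the scatter from compound 2. Among the compounds with values here, the only measured step between compounds differing in one place is a 2.8-fold lower number from compound 2 to compound 3 (0.45 log units; beyond the scatter).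

Compound 4 `CCOC(=O)c1sc2ccc(NCc3nc[nH]c3C)cc2c1NC(=O)c1cc(OC)c(OC)c(OC)c1` has not yet been measured. It differs from compound 3 in one place: 3,4,5-trimethoxyphenyl in place of 4-methoxyphenyl on a carbonyl carbon. Within the data shown here, no measured pair shows exactly this exchange. Two pieces of evidence bear on it. First, the step from compound 2 to compound 3 shows that adding a single methoxy group brought a modest drop in this assay. Second, compound 1, which carries the same 3,4,5-trimethoxyphenyl group but differs from compound 3 elsewhere, gives a number within the scatter of compound 3. Together these point to a modest lowering at most, possibly none beyond the scatter. Compound 4 is therefore expected to give about 5000 nM in this assay, within a range from 2000 nM to 14000 nM. This estimate corresponds to an expected step of a 1.6-fold lower number from compound 3 to compound 4 (0.22 log units; within the scatter).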

Compound 4, concentration for 50% growth inhibition: 2230 nM
Compound 4: middle estimate off by 2.2-fold (0.35 log units), on the high side, within the range that was stated.
By their numbers in this assay, from the lowest: compound 4; then compounds 1 and 3 (each within the scatter of the next); then compound 2.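

In this assay, placing 3,4,5-trimethoxyphenyl on the carbonyl carbon instead of 4-methoxyphenyl gives a 3.7-fold lower number from compound 3 to compound 4 (0.57 log units; beyond the scatter) and so shows that the lowering seen with the first methoxy group goes further when the ring carries three of them. Measured from the bare phenyl, the same position gives a 10-fold lower number from compound 2 to compound 4 (1.02 log units; beyond the scatter) in all, which makes the group on this carbonyl carbon a strong handle on growth inhibition among these compounds, with phenyl, 4-methoxyphenyl and 3,4,5-trimethoxyphenyl falling in that order and no compound here going against it. The result also separates a second change that compounds 1 and 3 had left hidden, since they differ in two places: with 3,4,5-trimethoxyphenyl held fixed, the added methyl alone gives a 3.0-fold lower number from compound 1 to compound 4 (0.48 log units; beyond the scatter) as a step of its own. Still open, as far as these compounds go, is whether the lowering follows the number of methoxy groups or depends on each one, and how ethoxy or hydroxy groups in their place, or an ethyl in place of the methyl, would behave. Nothing measured here explains why either change lowers the number.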